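Benzylsulfanyl series: chloro to fluoro step on the benzyl ring

The source may hold more compounds than are shown below. What is called first, only, known or untested is meant among the compounds shown, and "the series" means these compounds.

Measured compounds, with their values in a functional assay on the whole organism (artery, strain albino) with Rattus norvegicus as the target, with a stated time of 360 min, at a dose of 10 mg/kg by the oral route; on this read-out lower numbers stand for less inhibition and higher numbers for more inhibition at the one dose given (going by the name of the read-out):
- compound 1 `COc1ccc(C2N=C(SCc3ccc(F)cc3)NC(C)=C2C(=O)Nc2ccc(F)cc2)cc1OC`: 37.1%
- compound 2 `CC1=C(C(=O)Nc2ccc(F)cc2)C(c2ccc([N+](=O)[O-])cc2)N=C(SCc2ccccc2)N1`: 38.7%
- compound 3 `CC1=C(C(=O)Nc2ccc(F)cc2)C(c2ccc([N+](=O)[O-])cc2)N=C(SCc2ccc(Cl)cc2)N1`: 39.7%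

Compound 3 sits highest of the three numbers in this assay, but its nearest neighbour is compound 2, and the gap a number 1 percentage points higher from compound 2 to compound 3 (within the scatter) lies within the scatter; compound 1 lies within the scatter of compound 3 as well. No ordering among the three can be claimed on these numbers.

Compound 4 `CC1=C(C(=O)Nc2ccc(F)cc2)C(c2ccc([N+](=O)[O-])cc2)N=C(SCc2ccc(F)cc2)N1` is not yet measured. The change from compound 3 is fluoro in place of chloro on an aromatic carbon. Among the compounds with values here, the only measured single-place step, a number 1 percentage points higher from compound 2 to compound 3 (within the scatter), concerns this same aromatic carbon and gave no movement beyond the scatter; a chloro-to-fluoro exchange has no direct precedent here, and compound 1 differs from compound 4 in a second place, so its value cannot be read as a step. On that basis no step beyond the scatter is expected in this assay, and the expected step is a number 0.7 percentage points lower from compound 3 to compound 4 (within the scatter). For compound 4 the estimated value in this assay is 39%, with a range from 30% to 48%.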

Compound 4, a percentage reported as inhibition, in the whole organism at one dose (the size of the read-out at that dose, not a potency): 33%
For compound 4 the middle estimate is 6 percentage points above the measured one; measured number inside the range.
By their numbers in this assay, from the lowest: compounds 4, 1, 2 and 3 (each within the scatter of the next).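

In this assay the 4-chlorobenzyl to 4-fluorobenzyl exchange gives a number 6.7 percentage points lower from compound 3 to compound 4 (within the scatter) and stays unresolved, and fluoro in place of hydrogen on the same aromatic carbon gives a number 5.7 percentage points lower from compound 2 to compound 4 (within the scatter) as the second reading, so hydrogen, chloro and fluoro at this position are not told apart on this read-out. Within the data shown here, the same compound also gives the first single-place reading at the saturated ring carbon, where 4-nitrophenyl in place of 3,4-dimethoxyphenyl gives a number 4.1 percentage points lower from compound 1 to compound 4 (within the scatter) and likewise shows no movement beyond the scatter. No measured evidence bears on these results.

Open, as far as these compounds go, is whether an amine or a carboxylic acid on this aromatic carbon would move the number beyond the scatter. Also open, from the compounds shown here alone, is whether a longer chain in place of the benzyl group on sulfur would do so.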